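Adding a Methoxy Group to a Weak Cell-Growth Inhibitor

The source may report more compounds than this note shows. Statements on the series, on what has been measured and on what is new or still open speak of the compounds shown alone.

This study concerns two measured compounds and one whose number is still to come. Compound 1, `COc1cccc(-n2cc(NC(=O)c3cccc(NS(=O)(=O)c4ccc(Cl)cc4)c3)cn2)c1`, gives 44400 nM in a functional assay on A549 cells (Homo sapiens) for inhibition, read by MTT assay, with a stated time of 48 h; a lower number here means a stronger inhibitor, a higher number a weaker inhibitor. Compound 2, `O=C(Nc1cnn(-c2ccccc2)c1)c1ccc(NS(=O)(=O)c2ccccc2)cc1`, gives 87100 nM in this assay. Compound 2 holds the highest of the two numbers, and its nearest neighbour is compound 1 with a number two steps lower on the scale shown, a gap that lies within the usual scatter; so no order between the two can be claimed, and both are weak inhibitors here.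

Compound 3, `COc1ccc(-n2cc(NC(=O)c3ccc(NS(=O)(=O)c4ccccc4)cc3)cn2)cc1`, differs from compound 2 in one place: methoxy in place of hydrogen on an aromatic carbon. Among the compounds with values here, no pair of measured compounds shows this particular change on its own, so its effect cannot be read from the data. Given that compound 2 sits at 87100 nM and that a single small group is all that changes, the step of a 1.2-fold lower number from compound 2 to compound 3 (0.09 log units; within the scatter) is expected to stay within the scatter, in no settled direction. Compound 3 is therefore estimated at 70000 nM, with a range from 25000 nM to 200000 nM.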

Compound 3, half-maximal inhibitory concentration: 85800 nM
The estimate for compound 3 lay 1.2-fold (0.09 log units) below the measured number; the range from low to high includes it.
By their numbers in this assay, from the lowest: compounds 1, 3 and 2 (each within the scatter of the next).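

Replacing hydrogen with methoxy on the six-membered aromatic ring of carbon only, para to a large group, turns phenyl into 4-methoxyphenyl, and in this assay this gives a 1.0-fold lower number from compound 2 to compound 3 (0.01 log units; within the scatter). Within the data shown here, this is the first change in this set that can be read on its own, because the two compounds differ in only one place, and it shows that compound 3 and compound 2 cannot be told apart in this assay. At this position, then, methoxy in place of hydrogen leaves the compound a weak inhibitor, and no information is available on what lies behind this result.

On these data alone, one group at one position says little about the position as a whole, so it remains open whether an amine, a carboxylic acid or a longer chain such as butoxy in the same place would shift the number beyond the scatter. As far as these compounds go, it is equally open whether methoxy would give the same result on a compound with a stronger starting value, since this single step starts from a weak inhibitor.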